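The compounds below may be only part of what the source reports. "The series", "measured", "known", "first", "only" and "open" are said of these compounds alone.

The measured compounds are compound 1 `O=C(/C=C1\CCc2ccc(F)cc21)NCCO` at 78%, compound 2 `NC(=O)/C=C1\CCc2cc(F)cc(F)c21` at 55% and compound 3 `O=C(/C=C1\CCc2c1ccc(F)c2F)NC1CC1` at 27% in a functional assay on the whole organism with Rattus norvegicus as the target, at a dose of 20 mg/kg by the oral route; on this read-out lower numbers stand for less inhibition and higher numbers for more inhibition at the one dose given (going by the name of the read-out).

Compound 1 stands highest of the three numbers. Its gap to compound 2 is beyond the usual scatter, and its wider gap to compound 3 is beyond it as well. No two of these compounds differ in one place only, so the values show only where each stands. Compound 4 `CCCNC(=O)/C=C1\CCc2ccc(F)cc21` differs from compound 1 in one place: methyl in place of hydroxy on a saturated chain carbon, two bonds along the chain from an amide-type nitrogen. Without a measured step of this kind to lean on, a modest downward step in this assay is expected, though one that may stay within the scatter. The expected step is a number 13 percentage points lower from compound 1 to compound 4 (beyond the scatter). Compound 4 is expected to give 65%, in the range 40% to 88%.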

Compound 4, a percentage reported as inhibition, in the whole organism at one dose (the size of the read-out at that dose, not a potency): 36%
Compound 4: middle estimate off by 29 percentage points, on the high side; the measured number lies below the stated range.
By their numbers in this assay, from the lowest: compounds 3 and 4 (each within the scatter of the next); then compound 2; then compound 1.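

Within the data shown here, the change from 2-hydroxyethyl to propyl gives the first step that can be read in this assay, and it is a number 42 percentage points lower from compound 1 to compound 4 (beyond the scatter). At this position, then, the one-atom swap of hydroxy for methyl is not neutral at the one dose given. No measurement available here accounts for the size of this step.

Still open, as far as these compounds go, is whether an amine or a carboxylic acid at the same chain end would keep the number, and whether a longer chain carrying the hydroxy would do so. Also open, from the compounds shown here alone, is whether the same change gives a similar step on the cores of compound 2 and compound 3.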